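Three Stilbene-Chalcone Hybrids and an Untested Chloro Analogue

This account rests on a few compounds, and the source may have more. Where it says the series, first, only, none or still open, it means among the compounds named here.

Measured so far:
Compound 1, `COc1ccc(/C=C/c2cc(OC)cc(OC)c2/C=C/C(=O)c2ccc(C(F)(F)F)cc2)cc1`, gives 7.8 ug/mL in a functional assay on A549 cells (Homo sapiens) for antiproliferative activity, read by MTT assay, with a stated time of 48 h; on this read-out lower numbers stand for stronger inhibition and higher numbers for weaker inhibition.
Compound 2, `COc1ccc(/C=C/c2cc(OC)cc(OC)c2/C=C/C(=O)c2ccccc2C)cc1`, gives 5.9 ug/mL in this assay.
Compound 3, `CCCCCCCCCCCCOc1ccc(C(=O)/C=C/c2c(/C=C/c3ccc(OC)cc3)cc(OC)cc2OC)cc1`, gives 7.9 ug/mL in this assay.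

The three numbers lie close together. The gaps from compound 2 to compound 1 and from compound 2 to compound 3 are both within the usual scatter of repeated measurements, so compound 2 cannot be told apart from the other two on these data; all three share one core and differ only in the ring attached to the carbonyl carbon.

Compound 4, `COc1ccc(/C=C/c2cc(OC)cc(OC)c2/C=C/C(=O)c2ccc(Cl)cc2)cc1`, has not been measured. It differs from compound 2 in one place: 4-chlorophenyl in place of 2-methylphenyl on a carbonyl carbon.

Going by the values given here, only one measured step bears on this kind of change. It swapped one ring on the carbonyl carbon for another: a 1.3-fold lower number from compound 1 to compound 2 (0.12 log units; within the scatter). That step stayed within the scatter, which suggests that the ring on the carbonyl carbon has so far made little visible difference in this assay. Compound 4 is therefore expected to behave much like compound 2, with a step of about a 1.1-fold higher number from compound 2 to compound 4 (0.04 log units; within the scatter), no larger than the scatter.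

For compound 4 the expected value in this assay is 6.5 ug/mL, with a likely range from 3.5 ug/mL to 12 ug/mL.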

Compound 4, half-maximal inhibitory concentration: 6.4 ug/mL
Estimate against measurement, compound 4: 1.0-fold (0.01 log units) above; measured number inside the range.
By their numbers in this assay, from the lowest: compounds 2, 4, 1 and 3 (each within the scatter of the next).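

In this assay the step of a 1.1-fold higher number from compound 2 to compound 4 (0.04 log units; within the scatter) lies within the scatter, so 4-chlorophenyl and 2-methylphenyl on a carbonyl carbon cannot be told apart here. Going by these compounds alone, the second step, a 1.2-fold lower number from compound 1 to compound 4 (0.09 log units; within the scatter), also lies within the scatter and adds a comparison the earlier compounds did not offer: chloro in place of trifluoromethyl on an aromatic carbon, with the rest of the molecule unchanged. Compounds 1, 2 and 4 now form a set of three rings on this carbonyl carbon, each within the scatter of the other two, although no measurement shown explains why these rings read so much alike.

The compounds shown leave open whether a different kind of group on this ring, such as an amine, a carboxylic acid or a hydroxyl group, would produce a step beyond the scatter, or whether the ring tolerates such changes as readily as it tolerates these. They also leave open whether these three rings would still read alike in any other test of activity.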